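Pyrazolylphenyl Amide in Place of a Chlorophenyl-ethenyl Amide

This account rests on a few compounds, and the source may have more. Where it says the series, first, only, none or still open, it means among the compounds named here.

Compound 1, `CCCN(CC[C@H]1CC[C@H](NC(=O)/C=C/c2cccc(Cl)c2)CC1)[C@H]1CCc2nc(N)sc2C1`: 1.2 nM
Compound 2, `CCCN(CC[C@H]1CC[C@H](NC(=O)/C=C/c2ccccc2Cl)CC1)[C@H]1CCc2nc(N)sc2C1`: 1.2 nM
Compound 3, `CCCN(CC[C@H]1CC[C@H](NC(=O)c2ccc(-n3ccnc3)cc2)CC1)[C@H]1CCc2nc(N)sc2C1`: 1.9 nM

All three share one core and differ only in the group on the carbonyl carbon of the amide. In an assay on brain for displacement of a labelled ligand from D(3) dopamine receptor (Rattus norvegicus) (a higher number here means a weaker inhibitor, a lower number a stronger inhibitor), compound 2 stands level with compound 1, and together they give the lowest numbers of the three; no change at the digits printed from compound 1 to compound 2 (within the scatter). Its furthest neighbour is compound 3: a 1.6-fold higher number from compound 2 to compound 3 (0.20 log units; within the scatter).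

Compound 4, `CCCN(CC[C@H]1CC[C@H](NC(=O)c2ccc(-n3cccn3)cc2)CC1)[C@H]1CCc2nc(N)sc2C1`, has not yet been measured. 4-(1H-pyrazol-1-yl)phenyl in place of 2-(2-chlorophenyl)ethenyl on a carbonyl carbon

Within the data shown here, two measured steps bear on this. The closest is the move to compound 3, which also swaps the chlorophenyl-ethenyl group for a phenyl carrying a five-membered aromatic ring with two hetero atoms on the carbonyl carbon: a 1.6-fold higher number from compound 2 to compound 3 (0.20 log units; within the scatter). The same kind of swap from compound 1 gave a 1.6-fold higher number from compound 1 to compound 3 (0.20 log units; within the scatter). Both stayed within the scatter. Compound 4 differs from compound 3 only in which five-membered ring sits on the phenyl, so the number is expected to land close to compound 3: compound 4 is estimated at 2 nM, with a range from 0.8 nM to 5 nM. The expected step is a 1.7-fold higher number from compound 2 to compound 4 (0.22 log units; within the scatter), which would be within the scatter.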

Compound 4, inhibition constant: 3 nM
Compound 4: middle estimate off by 1.5-fold (0.18 log units), on the low side; low and high end bracket the measured number.
By their numbers in this assay, from the lowest: compounds 1, 2, 3 and 4 (each within the scatter of the next, the first and the last beyond it).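

In this assay, among these compounds, the swap on the carbonyl carbon now passes the usual scatter for the first time, as 4-(1H-pyrazol-1-yl)phenyl replaces either chlorophenyl-ethenyl group (a 2.5-fold higher number from compound 2 to compound 4 (0.40 log units; beyond the scatter); a 2.5-fold higher number from compound 1 to compound 4 (0.40 log units; beyond the scatter)), although both steps are modest and compound 3 had stayed within the scatter of compound 1 and compound 2. The exchange of the five-membered ring alone cannot be told apart from repeat-measurement noise (a 1.6-fold higher number from compound 3 to compound 4 (0.20 log units; within the scatter)), so the data do not separate 1H-pyrazol-1-yl from 1H-imidazol-1-yl on an aromatic carbon, and the difference from the chlorophenyl-ethenyl compounds is visible only for compound 4. Nothing shown here gives a measured reason for the modest step from either chlorophenyl-ethenyl compound.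

The compounds shown leave open how a plain phenyl, or a phenyl carrying an amine or a carboxylic acid in place of the 1H-pyrazol-1-yl, would behave on the same carbonyl carbon. They also leave open whether the modest gap would hold in a repeated comparison, given that compound 3 lies within the scatter of all the others.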